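Notes on the sulfonyl aryl group, compounds 1 to 4

The compounds below may be only part of what the source reports. "The series", "measured", "known", "first", "only" and "open" are said of these compounds alone.

The three measured compounds share one core and differ only in the aryl group on the sulfonyl sulfur. In an assay on HEK293 cells for displacement of a labelled ligand from 5-hydroxytryptamine receptor 6 (Homo sapiens), with a stated time of 60 min, tested at 1 uM, in the presence of a further agent that is not named here (on this read-out higher numbers stand for a stronger effect at the one concentration tested and lower numbers for a weaker effect), compound 1 `COc1ccc(S(=O)(=O)NCCN2CCC(CCC(=O)c3cc(Cl)c(N)cc3OC)CC2)cc1Br` gives 72%, compound 2 `COc1ccc(S(=O)(=O)NCCN2CCC(CCC(=O)c3cc(Cl)c(N)cc3OC)CC2)cc1` gives 52% and compound 3 `COc1ccc(S(=O)(=O)NCCN2CCC(CCC(=O)c3cc(Cl)c(N)cc3OC)CC2)c(OC)c1` gives 45%. Compound 3 stands lowest of the three; its gap to compound 2 is within the scatter, while compound 1 lies beyond it. The steps read a number 20 percentage points lower from compound 1 to compound 2 (beyond the scatter), a number 27 percentage points lower from compound 1 to compound 3 (beyond the scatter) and a number 7 percentage points lower from compound 2 to compound 3 (within the scatter).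

Compound 4 `COc1cc(N)c(Cl)cc1C(=O)CCC1CCN(CCNS(=O)(=O)c2ccc(N)cc2)CC1` has not yet been measured. Its change from compound 3: 4-aminophenyl in place of 2,4-dimethoxyphenyl on a sulfonyl sulfur. Among the measured compounds shown here, two measured steps bear on it, both on the same sulfonyl aryl: a number 27 percentage points lower from compound 1 to compound 3 (beyond the scatter) and a number 7 percentage points lower from compound 2 to compound 3 (within the scatter). For the measured compounds named here, no measured compound carries an amino group on that ring, so no step shows its effect directly. On that basis the expected step is no change at the digits printed from compound 3 to compound 4 (within the scatter), that is none beyond the scatter, with a wide range because the steps of a number 20 percentage points lower from compound 1 to compound 2 (beyond the scatter) and a number 27 percentage points lower from compound 1 to compound 3 (beyond the scatter) were modest yet beyond the scatter. For compound 4 the estimate in this assay is 45%, expected between 25% and 65%.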

Compound 4, a percentage reported as inhibition, at one concentration (the size of the read-out at that concentration, not a potency): 46%
For compound 4 the middle estimate is 1 percentage points below the measured one; the range from low to high includes it.
By their numbers in this assay, from the lowest: compounds 3, 4 and 2 (each within the scatter of the next); then compound 1.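

In this assay the exchange of the whole aryl group on the sulfonyl sulfur for 4-aminophenyl reads as a number 1 percentage points higher from compound 3 to compound 4 (within the scatter) and the exchange of methoxy for amino as a number 6 percentage points lower from compound 2 to compound 4 (within the scatter), so an amino-bearing ring joins the two methoxy-bearing rings without bromo at one level, and a group with a hydrogen-bond donor on that ring gives a number no different from theirs. The step of a number 26 percentage points lower from compound 1 to compound 4 (beyond the scatter) shows that compound 1 remains the only one of the four set apart beyond the scatter, now against an aryl group without any methoxy as well. Nothing at hand gives a reason for any of these steps.

Still open, on these data alone, is whether chloro, iodo or trifluoromethyl in place of the bromo would hold the number of compound 1, and whether bromo added to the 4-aminophenyl ring would raise the number as the bromo of compound 1 does on its methoxy-bearing ring. Also open, as far as these compounds go, is whether a dimethylamino or acetamido group in place of the amino would leave the number of compound 4 at the same level.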